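The compounds below may be only part of what the source reports. "The series", "measured", "known", "first", "only" and "open" are said of these compounds alone.

Of the compounds shown here, three sharing one core have been measured in a physicochemical assay for lipophilicity, at pH 7.4; on this read-out higher numbers stand for higher lipophilicity and lower numbers for lower lipophilicity. Compound 1 `CNC(=O)c1cc(C(=O)NC2CC2)c(C)n(Cc2ccccc2)c1=O` gives 2.9. Compound 3 `CNC(=O)c1cc(C(=O)NC2CC2)cn([C@H](C)c2ccccc2)c1=O` gives 3.4. Compound 2 `CNC(=O)c1cc(C(=O)NCCO)cn(Cc2ccccc2)c1=O` gives 1.9, the lowest of the three numbers; the gap up to compound 1 and the larger gap up to compound 3 both lie beyond the usual scatter. No two of these three compounds differ in a single place, so no clean single-change step can be read from the measured set.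

Compound 4 `CNC(=O)c1cc(C(=O)NCCC(C)C)cn(Cc2ccccc2)c1=O` has not yet been measured. It differs from compound 2 in one place: isopropyl in place of hydroxy on a saturated chain carbon, two bonds along the chain from an amide-type nitrogen. The hydroxy leaves and the isopropyl enters, so that the 2-hydroxyethyl of compound 2 becomes an isopentyl in compound 4. Starting from the value of compound 2, 1.9, this change is expected to move this assay upward by a large step, well beyond the scatter. The expected step is a number 1.70 log units higher from compound 2 to compound 4 (beyond the scatter). Compound 4 is estimated at 3.6, with a likely range from 3 to 4.2.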

Compound 4, distribution coefficient: 4.8
Compound 4: the middle estimate sits 1.20 log units below what was measured; the measured number lies above the stated range.
By their numbers in this assay, from the lowest: compound 2; then compound 1; then compound 3; then compound 4.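

Among these compounds, this is the first single-change comparison in the set. In this assay, replacing the hydroxy with an isopropyl on the saturated chain gives a number 2.90 log units higher from compound 2 to compound 4 (beyond the scatter), a large step beyond the scatter, so this position on the chain can strongly shift the read-out even with the rest of the structure unchanged. The change removes one oxygen with its hydrogen-bond donor and acceptor and adds 3 carbons, and nothing available here explains the size of the step.

The compounds shown leave open how much of the step goes with losing the hydroxy and how much with gaining the carbons. A methoxy group, an amine or a plain hydrogen in place of the hydroxy, or a longer chain, would help to separate these two parts.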